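Aryl variation on a saturated ring carbon: cytotoxicity notes

This account rests on a few compounds, and the source may have more. Where it says the series, first, only, none or still open, it means among the compounds named here.

Measured compounds, with values in a functional assay on Ehrlich cells (Mus musculus) for cytotoxicity, tested at 100 ug/mL; on this read-out higher numbers stand for a stronger effect at the one concentration tested and lower numbers for a weaker effect:

compound 1 `COc1cc(N2C(N)=C(C#N)C(/C=C/c3ccccc3)C3=C2CC(C)(C)CC3=O)cc(OC)c1OC` gives 40%
compound 2 `COc1cc(N2C(N)=C(C#N)C(c3c(OC)ccc4ccccc34)C3=C2CC(C)(C)CC3=O)cc(OC)c1OC` gives 30%
compound 3 `COc1cc(N2C(N)=C(C#N)C(c3ccc(Cl)cc3Cl)C3=C2CC(C)(C)CC3=O)cc(OC)c1OC` gives 100%

Compound 3 holds the highest of the three numbers. The rise is large in both directions leading to it: a number 60 percentage points higher from compound 1 to compound 3 (beyond the scatter) and a number 70 percentage points higher from compound 2 to compound 3 (beyond the scatter). Between the other two the difference is small, a number 10 percentage points lower from compound 1 to compound 2 (within the scatter), so no order can be read between compound 1 and compound 2.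

Compound 4 `COc1cc(N2C(N)=C(C#N)C(c3ccc(C)cc3)C3=C2CC(C)(C)CC3=O)cc(OC)c1OC` is not yet measured. It differs from compound 3 in one place: 4-methylphenyl in place of 2,4-dichlorophenyl on a saturated ring carbon.

Among the compounds with values here, the steps that bear on this change are the two that end at compound 3, each a large gain on arrival at 2,4-dichlorophenyl from a different group on the same saturated ring carbon. Within the data shown here, compound 4 moves away from 2,4-dichlorophenyl again, to 4-methylphenyl, a group no measured compound carries, so the size of the step rests on the general picture that the other groups sit well below compound 3. A fall in this assay is therefore expected, of uncertain size.

For compound 4 the estimated value in this assay is 55%, with a range from 25% to 90%. This estimate corresponds to a number 45 percentage points lower from compound 3 to compound 4 (beyond the scatter).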

Compound 4, a percentage reported as activity, at one concentration (the size of the read-out at that concentration, not a potency): 90%
Beside the measured number, compound 4's estimate is 35 percentage points below it, and the stated range covers the measured number.
By their numbers in this assay, from the lowest: compounds 2 and 1 (each within the scatter of the next); then compounds 4 and 3 (each within the scatter of the next).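

In this assay, exchanging the aryl group on the saturated ring carbon gives a number 10 percentage points lower from compound 3 to compound 4 (within the scatter) and so leaves 4-methylphenyl and 2,4-dichlorophenyl indistinguishable, which shows that the strong effect at this position does not depend on chlorine atoms on the phenyl ring. Within the data shown here, the same group also separates clearly from the two weaker groups, with a number 60 percentage points higher from compound 2 to compound 4 (beyond the scatter) and a number 50 percentage points higher from compound 1 to compound 4 (beyond the scatter) on the same carbon, so among the four compounds the two substituted phenyl groups stand apart from 2-methoxynaphthalen-1-yl and 2-phenylethenyl, with no compound going against this split. Nothing available here bears on the reason for this result.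

On these data alone, it remains open whether plain phenyl, or a phenyl ring carrying a hydroxyl, an amine or a carboxylic acid in place of the methyl, would stay with compound 3 and compound 4 or fall to the level of the other two. As far as these compounds go, it is also open whether compound 3 and compound 4 would stay together across a range of concentrations, as the read-out here comes from a single one.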